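The compounds below may be only part of what the source reports. "The series", "measured", "known", "first", "only" and "open" are said of these compounds alone.

Measured compounds:
Compound 1 `CC1(C)[C@H]2CC[C@]1(C)N(Cc1cn(-c3cccc(F)c3)nn1)C(=O)C2`: 180 nM
Compound 2 `CC1(C)[C@H]2CC[C@]1(C)N(Cc1cn(-c3ccc(F)cc3)nn1)C(=O)C2`: 230 nM
Compound 3 `COc1ccccc1-n1cc(CN2C(=O)C[C@@H]3CC[C@@]2(C)C3(C)C)nn1`: 350 nM

All three numbers come from a functional assay on A549 cells (Homo sapiens) for inhibition, read by MTT assay, with a stated time of 24 h; on this read-out lower numbers stand for stronger inhibition and higher numbers for weaker inhibition. Compound 1 gives the lowest number of the three, yet its neighbours lie within the scatter: a 1.3-fold higher number from compound 1 to compound 2 (0.11 log units; within the scatter) and a 1.9-fold higher number from compound 1 to compound 3 (0.29 log units; within the scatter). The remaining pair is likewise close, with a 1.5-fold higher number from compound 2 to compound 3 (0.18 log units; within the scatter). Each of these steps swaps the group on the aromatic nitrogen of the shared core, and none of them moves this assay beyond the scatter.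

Compound 4 `CC1(C)[C@H]2CC[C@]1(C)N(Cc1cn(-c3ccccc3)nn1)C(=O)C2` has not yet been measured in this assay. It differs from compound 1 in one place: hydrogen in place of fluoro on an aromatic carbon. This is a change of the same kind as the measured steps, and smaller than the swap from compound 1 to compound 3. Since every swap on that ring so far stayed within the scatter, the step of a 1.4-fold higher number from compound 1 to compound 4 (0.14 log units; within the scatter) is expected to stay within the scatter as well, with no clear direction. Compound 4 is therefore estimated at 250 nM, in the range 120 nM to 520 nM.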

Compound 4, half-maximal inhibitory concentration: 70 nM
Beside the measured number, compound 4's estimate is 3.6-fold (0.55 log units) above it; measured number outside the range, below it.
By their numbers in this assay, from the lowest: compound 4; then compounds 1, 2 and 3 (each within the scatter of the next).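

In this assay, within the data shown here, the bare phenyl of compound 4 is the first change on this ring to move the number beyond the scatter: taking away the fluoro gives (a 2.6-fold lower number from compound 1 to compound 4 (0.41 log units; beyond the scatter)) and (a 3.3-fold lower number from compound 2 to compound 4 (0.52 log units; beyond the scatter)), while taking away the methoxy gives (a 5.0-fold lower number from compound 3 to compound 4 (0.70 log units; beyond the scatter)). Swapping one substituent for another left the number within the scatter, whereas having hydrogen in place of any substituent shown gave the lowest number, and none of the four compounds goes against this. Nothing at hand explains this gap.

Going by these compounds, whether hydrogen also gives a lower number than other groups on this ring, such as an amine, a carboxylic acid or a methyl group, remains open. The compounds also leave open how the phenyl compares with a longer alkyl chain on the aromatic nitrogen.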